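Replacing a Diol Chain with a Diacid Chain

This account rests on a few compounds, and the source may have more. Where it says the series, first, only, none or still open, it means among the compounds named here.

compound 1, `CCn1c(C(=O)NCCN)ccc1C(CC)(CC)c1ccc(OCS(=O)(=O)c2ccccc2)c(C)c1`: 6470 nM
compound 2, `CCn1c(C(=O)NCCO)ccc1C(CC)(CC)c1ccc(OCS(=O)(=O)c2ccccc2)c(C)c1`: 15500 nM
compound 3, `CCn1c(C(=O)N[C@H](CO)CCO)ccc1C(CC)(CC)c1ccc(OCS(=O)(=O)c2ccccc2)c(C)c1`: 28500 nM

In a functional assay on MCF7 cells (Homo sapiens) for antiproliferative activity, read by MTT assay, with a stated time of 24 h (on this read-out lower numbers stand for stronger inhibition and higher numbers for weaker inhibition), compound 3 holds the highest of the three numbers. Its gap to compound 2 is small: a 1.8-fold higher number from compound 2 to compound 3 (0.26 log units; within the scatter). The gap to compound 1 is clearer: a 4.4-fold higher number from compound 1 to compound 3 (0.64 log units; beyond the scatter).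

Compound 4, `CCn1c(C(=O)N[C@H](CCC(=O)O)C(=O)O)ccc1C(CC)(CC)c1ccc(OCS(=O)(=O)c2ccccc2)c(C)c1`, keeps the shared core and changes only the chain on the amide nitrogen: 1,3-dicarboxypropyl in place of 3-hydroxy-1-(hydroxymethyl)propyl on an amide-type nitrogen. The measured steps that bear on this are those that altered the same chain, namely a 2.4-fold higher number from compound 1 to compound 2 (0.38 log units; beyond the scatter) and a 4.4-fold higher number from compound 1 to compound 3 (0.64 log units; beyond the scatter); both raised the number modestly. Among the compounds with values here, no measured compound carries a carboxylic acid, so the guidance is loose. A further modest rise is expected, a 1.6-fold higher number from compound 3 to compound 4 (0.20 log units; within the scatter). For compound 4 the estimate is 45000 nM, with a range from 15000 nM to 140000 nM.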

Compound 4, half-maximal inhibitory concentration: > 50000 nM
Compound 4 ended at the assay's limit; the forecaster's own chance of this, stated with the estimate: 30%; middle value at least 1.1-fold (0.04 log units) away from the limit.
By their numbers in this assay, from the lowest: compound 1; then compounds 2 and 3 (each within the scatter of the next). At a limit, above all of these: compound 4.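

In this assay compound 4 gives no number but a limit: the limit of > 50000 nM in this assay, at which 1 of the 4 values shown sits.

As a floor, an at least 1.7-fold higher number from compound 3 to compound 4 (0.24 log units; that floor lies within the scatter), so the diacid chain cannot be told apart from the diol chain on this step, while an at least 3.2-fold higher number from compound 2 to compound 4 (0.50 log units; beyond the scatter) and an at least 7.7-fold higher number from compound 1 to compound 4 (0.88 log units; beyond the scatter). Thus 1,3-dicarboxypropyl on the amide-type nitrogen is the only chain shown that reaches the limit, and the only one with carboxylic acids.

Going by these compounds, how far past the limit compound 4 lies stays open. So does whether a single carboxylic acid, or a methyl ester of the diacid, would behave the same way at this position.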